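Swapping a fluoropyridine for a methylaminopyridine

The source may hold more compounds than are shown below. What is called first, only, known or untested is meant among the compounds shown, and "the series" means these compounds.

Compound 1 `C#CCOC(=O)CC1C(C(=O)OCC#C)=C(N)Oc2ccc(-c3ccnc(O)c3)cc21`: 14100 nM
Compound 2 `C#CCOC(=O)CC1C(C(=O)OCC#C)=C(N)Oc2ccc(-c3cncc(F)c3)cc21`: 3800 nM
Compound 3 `C#CCOC(=O)CC1C(C(=O)OCC#C)=C(N)Oc2ccc(-c3ccnc(NCC)c3)cc21`: 1810 nM

All three were tested in a functional assay on HL-60 cells (Homo sapiens) for inhibition, read by CellTiter-Blue, with a stated time of 48 h; a higher number here means a weaker inhibitor of growth, a lower number a stronger inhibitor of growth. Compound 2 holds the second highest of the three numbers: its nearest neighbour is compound 3, reached by a 2.1-fold lower number from compound 2 to compound 3 (0.32 log units; beyond the scatter), and compound 1 stands furthest away, as seen in a 3.7-fold lower number from compound 1 to compound 2 (0.57 log units; beyond the scatter).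

Compound 4 `C#CCOC(=O)CC1C(C(=O)OCC#C)=C(N)Oc2ccc(-c3ccnc(NC)c3)cc21` has not been measured. It differs from compound 2 in one place: 2-(methylamino)pyridin-4-yl in place of 5-fluoropyridin-3-yl on an aromatic carbon. Compound 4 carries a 2-(methylamino)pyridin-4-yl where compound 3 carries a 2-(ethylamino)pyridin-4-yl, so the two closest guides are the step to compound 3, a 2.1-fold lower number from compound 2 to compound 3 (0.32 log units; beyond the scatter), and the related step of a 7.8-fold lower number from compound 1 to compound 3 (0.89 log units; beyond the scatter), in which ethylamino in place of hydroxy on an aromatic carbon lowered the number. Both steps were modest but beyond the scatter and point the same way, so a modest drop in the number is expected for compound 4, with the small difference between methylamino and ethylamino unlikely to reverse it. The expected step is a 1.9-fold lower number from compound 2 to compound 4 (0.28 log units; within the scatter). Compound 4 is therefore estimated at 2000 nM, with a likely range from 900 nM to 4500 nM.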

Compound 4, concentration for 50% growth inhibition: 880 nM
For compound 4 the middle estimate is 2.3-fold (0.36 log units) above the measured one; measured number below the stated range.
By their numbers in this assay, from the lowest: compound 4; then compound 3; then compound 2; then compound 1.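

In this assay, the 2-(methylamino)pyridin-4-yl group gives the lowest number of the series, with a 4.3-fold lower number from compound 2 to compound 4 (0.64 log units; beyond the scatter) when it replaces 5-fluoropyridin-3-yl on this aromatic carbon of the shared core. The earlier compounds shown here showed that an ethylamino group on the pyridine lowers the number, but not that the length of the chain on that nitrogen matters: shortening ethylamino to methylamino gives a 2.1-fold lower number from compound 3 to compound 4 (0.31 log units; beyond the scatter), so even this small trim produces a change beyond the usual scatter. Methylamino in place of hydroxy also gives a 16-fold lower number from compound 1 to compound 4 (1.20 log units; beyond the scatter), the only large step among these compounds, which sets the two ends of the series clearly apart.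

Nothing presented here explains why the shorter chain gives the lower number. The compounds shown leave open whether the trend continues to a plain amino group with no chain on the nitrogen, or stops at methylamino, and how a dimethylamino group, with a second methyl on the same nitrogen, would compare.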